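Methyl for fluoro on the aryl ring: series notes

The compounds below may be only part of what the source reports. "The series", "measured", "known", "first", "only" and "open" are said of these compounds alone.

Compound 1 `Oc1ccccc1CNc1ccc(-c2ccc(F)cc2)cc1` and compound 2 `Cc1ccc(-c2ccc(NCc3ccccc3O)cc2)cc1` share one core. In a functional assay on Jurkat cells (Homo sapiens) for activation, with a stated time of 24 h (a lower number here means that less compound is needed, a higher number that more compound is needed for the effect), compound 1 gives 3860 nM, and compound 2 gives 3790 nM. The change methyl in place of fluoro on an aromatic carbon produced a 1.0-fold lower number from compound 1 to compound 2 (0.01 log units; within the scatter). Compound 3 `Oc1ccccc1CNc1ccc(-c2ccccc2)cc1F` has the same atoms joined differently; how its core differs from the core of compound 1 is not broken down here. In this assay compound 3 gives 5350 nM. Compound 4 `Cc1cc(-c2ccccc2)ccc1NCc1ccccc1O`, not yet measured, differs from compound 3 by methyl in place of fluoro on an aromatic carbon. This is the same kind of change as that from compound 1 to compound 2, not the same: there the place was para to a large group, here it is ortho to a group of 9 heavy atoms and meta to a phenyl group. For compound 4 the expected step in this assay is a 1.1-fold lower number from compound 3 to compound 4 (0.05 log units; within the scatter), a flat step expected because a 1.0-fold lower number from compound 1 to compound 2 (0.01 log units; within the scatter) stayed within the scatter. Compound 4 is estimated at 4800 nM, with a range from 2000 nM to 11000 nM.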

Compound 4, half-maximal effective concentration: "not active" (no number reported)
Nothing numeric was reported for compound 4; the estimate stays without a comparison.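

Among these compounds, compound 4 is reported as "not active" in this assay, with no number, and no step from compound 3 to compound 4 can be read. Nothing shown accounts for this result. The compounds shown leave open whether methyl in place of fluoro at this place differs from the same change between compound 1 and compound 2.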